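A Urea Swap at the Cytotoxicity Limit

The compounds below may be only part of what the source reports. "The series", "measured", "known", "first", "only" and "open" are said of these compounds alone.

Measured in an ADME assay on HEK-293T cells (Homo sapiens) for cytotoxicity, read by CCK-8 assay, with a stated time of 48 h; on this read-out higher numbers stand for weaker inhibition and lower numbers for stronger inhibition:
compound 1 `COc1ccc(Oc2ccc([N+](=O)[O-])cc2-c2ccsc2S(=O)(=O)N2CCN(C(=S)Nc3ccc(Cl)cc3)CC2)cc1OC`: > 50000 nM
compound 2 `O=C(Nc1cccc([N+](=O)[O-])c1)N1CCN(S(=O)(=O)c2sccc2-c2ccccc2Oc2ccc(O)c(O)c2)CC1`: > 20000 nM
compound 3 `O=C(NCCNS(=O)(=O)c1ccc(-c2ccccc2OCc2cccc(O)c2)s1)Nc1cc(C(F)(F)F)cc(C(F)(F)F)c1`: > 20000 nM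

All three entries are limits of this assay and not numbers. Compound 1 stands at a limit, > 50000 nM, and it is the only one of the three at the limit of > 50000 nM in this assay, at which 1 of the 3 values shown sits. The other two sit at the limit of > 20000 nM in this assay, at which 2 of the 3 values shown sit.

Compound 4 `COc1ccc(Oc2ccc([N+](=O)[O-])cc2-c2ccsc2S(=O)(=O)N2CCN(C(=O)Nc3ccc([N+](=O)[O-])cc3)CC2)cc1OC` keeps the core of compound 1 and changes one group, on an amine nitrogen in a ring: a group of 12 heavy atoms (7 carbon, 2 nitrogen, 3 oxygen; one six-membered aromatic ring of carbon only) in place of a group of 10 heavy atoms (7 carbon, 1 nitrogen, 1 sulfur, 1 chlorine; one six-membered aromatic ring of carbon only), on an amine nitrogen in a ring. The group that enters is (4-nitrophenyl)carbamoyl. Within the data shown here, no step between measured compounds is available to size this change. The expectation therefore rests on the limits alone, and a shift beyond the usual scatter in this assay is not expected. Compound 2 also gives only a limit, > 20000 nM, and this supports that expectation. The estimated change is a number no higher from compound 1 to compound 4 (the limit leaves the size open), and it is expected to be no real change. Compound 4 is expected at about 50000 nM, with an estimated range of 20000 nM to 100000 nM.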

Compound 4, half-maximal inhibitory concentration: > 20000 nM
Compound 4: no number, only a limit (the forecaster's own chance of this, stated with the estimate: 80%); the middle value does not contradict the limit.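

In this assay compound 4 gives > 20000 nM, a limit and not a number. Among these compounds, compound 1 also gives only a limit, so no step between compound 1 and compound 4 can be read. The compounds shown leave open whether (4-nitrophenyl)carbamoyl changes the read-out in this assay at all.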